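A Pyrrolidine Ester Replaces Chlorine in a Benzothiazole Series

This account rests on a few compounds, and the source may have more. Where it says the series, first, only, none or still open, it means among the compounds named here.

Compound 1 `COc1cc(-c2nc3ccccc3s2)ccc1OCC(=O)NNC(=O)CCl` is the reference point. In a functional assay on HepG2 cells (Homo sapiens) for inhibition, read by MTT assay, with a stated time of 3 days (on this read-out higher numbers stand for weaker inhibition and lower numbers for stronger inhibition), compound 1 gives 2890 nM, the lowest of the two numbers recorded so far; compound 2 `CCOC(=O)[C@H](CCSC)NCC(=O)NNC(=O)COc1ccc(-c2nc3ccccc3s2)cc1OC` gives 3330 nM in this assay, and the change a 1.2-fold higher number from compound 1 to compound 2 (0.06 log units; within the scatter) shows that exchanging the chloro group for a larger amino acid ester left the read-out essentially unchanged.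

Compound 3 `CCOC(=O)[C@@H]1CCCN1CC(=O)NNC(=O)COc1ccc(-c2nc3ccccc3s2)cc1OC` has not yet been measured. It differs from compound 1 in one place: 2-(ethoxycarbonyl)pyrrolidin-1-yl in place of chloro on a saturated chain carbon bound to a carbonyl carbon. Among the measured compounds shown here, this is the only measured step that bears on it, and it was flat, so a similarly small step in this assay is expected for compound 3, with no movement beyond the scatter in either direction. The estimated value for compound 3 is 3300 nM, with a range from 1500 nM to 7500 nM, corresponding to an expected step of a 1.1-fold higher number from compound 1 to compound 3 (0.06 log units; within the scatter).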

Compound 3, half-maximal inhibitory concentration: 2800 nM
Beside the measured number, compound 3's estimate is 1.2-fold (0.07 log units) above it, within the range that was stated.
By their numbers in this assay, from the lowest: compounds 3, 1 and 2 (each within the scatter of the next).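

In this assay, the 2-(ethoxycarbonyl)pyrrolidin-1-yl group gives a second replacement of chloro on a saturated chain carbon bound to a carbonyl carbon, with a 1.0-fold lower number from compound 1 to compound 3 (0.01 log units; within the scatter). Set against the open-chain group of compound 2, this five-membered ring gives a 1.2-fold lower number from compound 2 to compound 3 (0.08 log units; within the scatter), so among these three compounds neither the loss of chloro nor the presence of the ring moves the read-out beyond the scatter. Nothing available explains why the three numbers lie so close together.

As far as these compounds go, it remains open whether a free carboxylic acid in place of the ethyl ester, or a small dimethylamino group in place of chloro, would also stay within the scatter at this place. From the compounds shown here alone, the opposite configuration at the defined stereocentre of the pyrrolidine ring is equally open.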